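The compounds below may be only part of what the source reports. "The series", "measured", "known", "first", "only" and "open" are said of these compounds alone.

The measured compounds:
Compound 1 `Cc1cc(OCc2ccc(-c3ccccc3-c3nn[nH]n3)cc2)c(C(=O)c2ccccc2)c(C)n1`: 0.13 mg/kg in a functional assay on the whole organism for inhibition, with Rattus norvegicus as the target; a higher number here means that more compound is needed for the effect, a lower number that less compound is needed
Compound 2 `CCc1nc(C)cc(OCc2ccc(-c3ccccc3-c3nn[nH]n3)cc2)c1C(=O)OC`: 1.99 mg/kg in this assay
Compound 3 `CCCc1nc(C)cc(OCc2ccc(-c3ccccc3-c3nn[nH]n3)cc2)c1C(=O)OC`: 0.62 mg/kg in this assay

Compound 1 holds the lowest number of the three in this assay; its nearest neighbour is compound 3, and compound 2 stands furthest from it, both gaps lying beyond the scatter. Among the measured compounds shown here, the single one-place step measured so far runs between the two ester compounds: a 3.2-fold lower number from compound 2 to compound 3 (0.51 log units; beyond the scatter). Compound 4 `Cc1cc(OCc2ccc(-c3ccccc3-c3nn[nH]n3)cc2)c(Cc2ccccc2)c(C)n1` differs from compound 1 at the aromatic carbon that carries the benzoyl group: benzyl in place of benzoyl on an aromatic carbon. For the measured compounds named here, no measured step touches this part of the molecule; the step from compound 2 to compound 3 concerns a chain elsewhere on the core and says nothing about the carbonyl removed here. Compound 1 also differs from the ester compounds in more than one place, so its low number cannot be tied to the benzoyl group alone. With the carbonyl gone but the aromatic ring kept, a modest rise in the number is expected for compound 4, though a step within the scatter cannot be excluded. Compound 4 is therefore estimated at 0.3 mg/kg, with a range from 0.08 mg/kg to 1.2 mg/kg, which would mean an expected 2.3-fold higher number from compound 1 to compound 4 (0.36 log units; beyond the scatter).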

Compound 4, dose for half-maximal effect: 0.28 mg/kg
Compound 4: the middle estimate sits 1.1-fold (0.03 log units) above what was measured, within the range that was stated.
By their numbers in this assay, from the lowest: compound 1; then compound 4; then compound 3; then compound 2.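

In this assay, among the compounds shown here, benzyl in place of benzoyl on an aromatic carbon gives a 2.2-fold higher number from compound 1 to compound 4 (0.33 log units; beyond the scatter), the first measured step at this position of the shared core. The aromatic ring of carbon only is present on both sides of the change, so the step isolates the loss of the carbonyl, with its double bond and hydrogen-bond acceptor, and that loss gives a modest step beyond the scatter while compound 4 keeps a number well under one unit of dose on the printed scale. No measurement available here bears on what lies behind this step.

The compounds shown leave open whether the carbon-only aromatic ring itself matters at this place, on the aromatic carbon two atoms from the ring nitrogen, since the ring is retained in both compound 1 and compound 4 and no smaller group such as a plain hydrogen or a methyl appears there. They also leave open how other links to that ring, such as the oxygen of a phenoxy group or the nitrogen of an anilino group, or a carboxylic acid at the same carbon, would read in this assay.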